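Selenium for Sulfur: Expected Cytotoxicity of Compound 4

This account rests on a few compounds, and the source may have more. Where it says the series, first, only, none or still open, it means among the compounds named here.

Measured so far:
Compound 1 `CS/C(=N\C(=O)c1csc([N+](=O)[O-])c1)NC(=O)c1csc([N+](=O)[O-])c1` gives 63400 nM in a functional assay on HepG2 cells (Homo sapiens) for cytotoxicity, read by MTT assay, with a stated time of 72 h; a lower number here means a stronger inhibitor of growth, a higher number a weaker inhibitor of growth.
Compound 2 `CS/C(=N\C(=O)c1ccco1)NC(=O)c1ccco1` reaches only a limit of this assay, > 100000 nM.
Compound 3 `O=C(/N=C(/NC(=O)c1ccco1)[Se]Cc1ccccc1)c1ccco1` gives 7650 nM.

Compound 2 and compound 3 share a core and differ in one place: a group of 8 heavy atoms (7 carbon, 1 selenium; one six-membered aromatic ring of carbon only) in place of a group of 2 heavy atoms (1 carbon, 1 sulfur; no ring), on a carbon with a double bond to nitrogen. This change produced an at least 13-fold lower number from compound 2 to compound 3 (1.11 log units; beyond the scatter). Compound 2 sits at a limit (the limit of > 100000 nM in this assay, at which 1 of the 3 values shown sits), so that step is known only as a minimum. Compound 4 `O=C(/N=C(/NC(=O)c1csc([N+](=O)[O-])c1)[Se]Cc1ccccc1)c1csc([N+](=O)[O-])c1` has not yet been measured. It relates to compound 1 exactly as compound 3 relates to compound 2, through the same change: a group of 8 heavy atoms (7 carbon, 1 selenium; one six-membered aromatic ring of carbon only) in place of a group of 2 heavy atoms (1 carbon, 1 sulfur; no ring), on a carbon with a double bond to nitrogen. How the core of compound 1 differs from the core of compound 2 is not broken down here. Compound 1 and compound 3 already stand apart beyond the scatter, compound 1 giving the higher number of the two.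

For compound 4 the expected step is a 14-fold lower number from compound 1 to compound 4 (1.15 log units; beyond the scatter), which rests on the measured step of an at least 13-fold lower number from compound 2 to compound 3 (1.11 log units; beyond the scatter) repeated on the core of compound 1. Compound 4 is therefore estimated at 4500 nM, with a likely range from 1200 nM to 16000 nM.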

Compound 4, concentration for 50% growth inhibition: 34100 nM
Compound 4: middle estimate off by 7.6-fold (0.88 log units), on the low side; the measured number lies above the stated range.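

The same change on the second core gave a 1.9-fold lower number from compound 1 to compound 4 (0.27 log units; within the scatter), so in this assay it did not carry over with the size it had on the first core: the same change on two cores in this assay, an at least 13-fold lower number (1.11 log units; beyond the scatter) from compound 2 to compound 3 and a 1.9-fold lower number (0.27 log units; within the scatter) from compound 1 to compound 4, at least 7.0-fold (0.84 log units) apart, beyond the scatter of two such steps The earlier step is known only as a minimum, and compound 2 gives not a number but a limit of the assay, > 100000 nM. These two pairs show that the size of this step depended on the core, but they do not show which part of the core matters, how large the earlier step really is, or what selenium contributes apart from the aromatic ring that enters with it.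

The compounds shown leave open how a methyl group on selenium, or the same ring-bearing group on sulfur, would behave on either core, which would pull the two parts of the change apart. They also leave open whether a core with an amine in place of each nitro group would follow compound 1 or compound 2.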